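A few compounds are considered here, and "the series" means these few. Any claim that something is new, unique, unknown or untested is made for them only; others in the source may bear on it.

Of the compounds shown here, three built on one shared core have been tested in a functional assay on MCF7 cells (Homo sapiens) for inhibition, read by MTT assay, with a stated time of 24 h; on this read-out higher numbers stand for weaker inhibition and lower numbers for stronger inhibition. Compound 1 `CCOC(=O)C1=Cc2ccccc2OC1(OCc1cc(-c2ccc(C)cc2)no1)C(F)(F)F` carries an ethyl ester, and in this assay compound 1 gives only a limit, > 150000 nM. Compound 3 `CCOC(=O)C1=Cc2ccccc2OC1(OCc1cn(-c2ccccc2)nn1)C(F)(F)F` keeps the same ester on a core that differs elsewhere, and in this assay compound 3 likewise gives only a limit, > 150000 nM. Compound 2 `Cc1ccc(-c2cc(COC3(C(F)(F)F)Oc4ccccc4C=C3C(=O)O)on2)cc1` is the free acid, and in this assay compound 2 gives 30100 nM. Within the data shown here, that is the only actual number among the three, since the limit of > 150000 nM in this assay, at which 2 of the 3 values shown sit, covers the other two values. Among the measured compounds shown here, the single measured step, an at least 4.9-fold lower number from compound 1 to compound 2 (0.69 log units; beyond the scatter), is all that is known about how the read-out moves.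

Compound 4 `O=C(O)C1=Cc2ccccc2OC1(OCc1cc(-c2cccc(C(F)(F)F)c2)no1)C(F)(F)F` keeps the acid of compound 2 and changes only one substituent: 3-(trifluoromethyl)phenyl in place of 4-methylphenyl on an aromatic carbon. For the measured compounds named here, no measured step touches an exchange of this kind, so the ester-to-acid step offers no guide to its size or direction, and the expectation is a step no larger than the usual scatter. Compound 4 is therefore estimated at 30000 nM, with a range from 10000 nM to 100000 nM, which means an expected step of a 1.0-fold lower number from compound 2 to compound 4 (0.00 log units; within the scatter).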

Compound 4, half-maximal inhibitory concentration: > 150000 nM
Compound 4: no number, only a limit; the forecaster's own chance of this, stated with the estimate: 20%; middle value at least 5.0-fold (0.69 log units) away from the limit.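

Exchanging 4-methylphenyl for 3-(trifluoromethyl)phenyl on this aromatic carbon is not a neutral swap: in this assay it gives an at least 4.9-fold higher number from compound 2 to compound 4 (0.69 log units; beyond the scatter). Compound 4 keeps the free acid and still gives only a limit, > 150000 nM, so the acid alone does not secure a measurable inhibition here, and the group at this position matters as well. Compound 2 therefore remains the only one with an actual number, while the others share a single limit: the limit of > 150000 nM in this assay, at which 3 of the 4 values shown sit.

From the compounds shown here alone, how far compound 4 really lies from compound 2 stays unknown, since its value is a limit and not a number. Going by these compounds, the exchange also alters both the substituent and its place on the phenyl ring, so it remains open how a plain phenyl, or a chlorine or methoxy group on that ring, would read out.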